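A few compounds are considered here, and "the series" means these few. Any claim that something is new, unique, unknown or untested is made for them only; others in the source may bear on it.

The measured compounds and their values:

Compound 1, `CC(=O)c1ccc(NC(=O)C(C(C)C)N(C(=O)c2ccccc2)S(=O)(=O)c2ccc([N+](=O)[O-])cc2)cc1`: 6800000 nM
Compound 2, `CC(=O)c1ccc(NC(=O)C2CC(O)CN2S(=O)(=O)c2ccc([N+](=O)[O-])cc2)cc1`: 7100000 nM
Compound 3, `CC(=O)c1ccc(NC(=O)C(C(C)C)N(C(=O)c2ccccc2)S(=O)(=O)c2ccccc2)cc1`: 13000000 nM

These three compounds were tested in a functional assay, read by spectrophotometry, with a stated time of 20 min; on this read-out lower numbers stand for stronger inhibition and higher numbers for weaker inhibition. In this assay compound 1 gives 6800000 nM, compound 2 gives 7100000 nM and compound 3 gives 13000000 nM, so all three inhibit only weakly and lie close to one another.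

Compounds 1 and 3 differ in one place: hydrogen in place of nitro on an aromatic carbon. This change gives a 1.9-fold higher number from compound 1 to compound 3 (0.28 log units; within the scatter), a step that stays within the usual scatter of repeated measurements, so it cannot be read as a real change in this assay.

Compound 4, `CC(=O)c1ccc(NC(=O)C2CC(O)CN2S(=O)(=O)c2ccccc2)cc1`, has not yet been measured. It differs from compound 2 in the same way: hydrogen in place of nitro on an aromatic carbon. The difference between the core of compound 2 and the core of compound 1 is not broken down here.

Because the same change gave a 1.9-fold higher number from compound 1 to compound 3 (0.28 log units; within the scatter), compound 4 is expected to show a step of about a 1.7-fold higher number from compound 2 to compound 4 (0.23 log units; within the scatter). The estimate for compound 4 in this assay is 12000000 nM, most likely between 5000000 nM and 30000000 nM.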

Compound 4, half-maximal inhibitory concentration: 3800000 nM
Estimate against measurement, compound 4: 3.2-fold (0.50 log units) above, outside the stated range (below it).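

In this assay, replacing the nitro of the 4-nitrophenyl group with hydrogen gives a 1.9-fold lower number from compound 2 to compound 4 (0.27 log units; within the scatter), a step that on its own stays within the usual scatter. Set beside the earlier step, the same change does not behave alike on the two cores, and the gap between the two steps is larger than the scatter of repeated measurements can account for: the same change on two cores in this assay, a 1.9-fold higher number (0.28 log units; within the scatter) from compound 1 to compound 3 and a 1.9-fold lower number (0.27 log units; within the scatter) from compound 2 to compound 4, 3.6-fold (0.55 log units) apart, beyond the scatter of two such steps This shows that, in these compounds, the step seen on one core cannot simply be carried over as a fixed shift to predict the other, but with only two pairs and all values weak, it does not show what in the cores is responsible or how general the gap is.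

The compounds shown leave open whether another group in the same place, such as an amine or a carboxylic acid, would also give different steps on the two cores. They also leave open which of the several differences between the two cores matters.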